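The source may hold more compounds than are shown below. What is called first, only, known or untested is meant among the compounds shown, and "the series" means these compounds.

In an ADME assay on HEK-293T cells (Homo sapiens) for inhibition, read by CCK-8 assay, with a stated time of 48 h, tested at 20 uM (a lower number here means less inhibition of growth, a higher number more inhibition of growth at the concentration tested), compound 1 (`Cc1ccc(S(=O)(=O)Oc2ccccc2/C=C(\C#N)C(=O)Nc2nnc(Cc3cccc4ccccc34)s2)cc1`) gives 23% and compound 2 (`COc1ccc(S(=O)(=O)Oc2ccccc2/C=C(\C#N)C(=O)Nc2nnc(Cc3cccc4ccccc34)s2)cc1`) gives 29% on the shared core. Compound 3 (`N#C/C(=C\c1ccccc1OS(=O)(=O)c1ccccc1[N+](=O)[O-])C(=O)Nc1nnc(Cc2cccc3ccccc23)s1`) has no single number and stands only as "not toxic" (no number reported) in the record, so it offers no exact starting point. Compound 4 (`N#C/C(=C\c1ccccc1OS(=O)(=O)c1ccccc1[N+](=O)[O-])C(=O)Nc1nnc(Cc2cccc(F)c2)s1`) differs from compound 3 in one place, and 3-fluorophenyl in place of naphthalen-1-yl on a saturated chain carbon bound to an aromatic carbon sums up that change. The same difference, cut one bond further out, reads (naphthalen-1-yl)methyl to 3-fluorobenzyl. Among the compounds with values here, the only measured step is a number 6 percentage points higher from compound 1 to compound 2 (within the scatter) and it comes from methoxy in place of methyl on an aromatic carbon, which is a different change from this one. No measurement covers the loss of naphthalen-1-yl, so no step beyond the scatter can be expected in this assay and no direction can be named. The expectation therefore leans on compound 1 at 23% and compound 2 at 29% as the nearest numbers, pulled down a little by the verdict on compound 3. Compound 4 is expected at 18% with an estimated range from 3% to 35% in this measurement.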

Compound 4, percent growth inhibition at one concentration: "not toxic" (no number reported)
Nothing numeric was reported for compound 4, so the estimate cannot be set against anything.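

In this assay compound 3 and compound 4 each carry only a verdict with no number, and no step can be read between them. Going by these compounds, how far growth inhibition shifts with 3-fluorophenyl in place of naphthalen-1-yl stays open. No supporting evidence bears on this result.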